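Swapping Nitro for Trifluoromethyl at the Assay Limit

This account rests on a few compounds, and the source may have more. Where it says the series, first, only, none or still open, it means among the compounds named here.

Values in an ADME assay on BE(2)-C cells (Homo sapiens) for cytotoxicity, read by MTT assay, with a stated time of 20 h (on this read-out lower numbers stand for higher toxicity in this test and higher numbers for lower toxicity in this test), as measured so far:
- compound 1 `O=C(NCCCc1ccncc1)C1CCN(C(=O)c2cc3ccccc3n2Cc2ccc(Cl)cc2)CC1` gives 71500 nM
- compound 2 `CN(C)C(=O)C1CCN(C(=O)c2cc3ccccc3n2Cc2ccc(Cl)cc2)CC1` gives > 100000 nM (a limit)
- compound 3 `CN(Cc1ccccc1)C(=O)C1CCN(C(=O)c2cc3ccccc3n2Cc2ccc([N+](=O)[O-])cc2)CC1` gives > 100000 nM (a limit)

Compound 3 stands at the limit of > 100000 nM in this assay, at which 2 of the 3 values shown sit, and so offers a limit rather than a number. Compound 4 `CN(Cc1ccccc1)C(=O)C1CCN(C(=O)c2cc3ccccc3n2Cc2ccc(C(F)(F)F)cc2)CC1` has not yet been measured. It carries trifluoromethyl in place of nitro on an aromatic carbon, para to a large group, and the change counts as follows: trifluoromethyl in place of nitro on an aromatic carbon with the rest of the structure untouched.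

Among the compounds with values here, no measured step covers this exchange. Within the data shown here, the only step available is an at least 1.3-fold higher number from compound 1 to compound 2 (0.14 log units; that floor lies within the scatter) and it concerns dimethylamino in place of (3-(pyridin-4-yl)propyl)amino on a carbonyl carbon, so it bears on this change only loosely. Starting from compound 3 at the limit of > 100000 nM in this assay, at which 2 of the 3 values shown sit, and with that step as the only guide, the expected step is a number no higher from compound 3 to compound 4 (the limit leaves the size open) and thus none beyond the scatter in this assay in either direction. For compound 4 the expected value is 100000 nM with an estimated range of 50000 nM to 200000 nM and a reading that may well be only a limit.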

Compound 4, half-maximal cytotoxic concentration: 90300 nM
Compound 4: middle estimate off by 1.1-fold (0.04 log units), on the high side, within the range that was stated.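

With trifluoromethyl in place of nitro on an aromatic carbon, para to a large group, the reading can be stated as a number: in this assay, compound 4 gives 90300 nM. Within the data shown here, the exchange is now covered by a step of its own, an at least 1.1-fold lower number from compound 3 to compound 4 (0.04 log units; that floor lies within the scatter), so the change in this position has a direct measure for the first time, not just a loose guide from a different part of the structure. Only the floor of that step can be read, since compound 3 carries a limit: the limit of > 100000 nM in this assay, at which 2 of the 4 values shown sit.

As far as these compounds go, the true size of the step therefore remains open. So does how a nitrile, an amine or a carboxylic acid in this position would read in this assay, or whether the exchange would read the same with a different amide.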